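The source may report more compounds than this note shows. Statements on the series, on what has been measured and on what is new or still open speak of the compounds shown alone.

Measured compounds:
Compound 1, `C#CCN(Cc1ccc2nc(C)nc(O)c2c1)c1ccccc1`, in a functional assay on L1210 cells (Mus musculus) for inhibition (on this read-out higher numbers stand for weaker inhibition and lower numbers for stronger inhibition), gives only a limit, > 6500 nM.
Compound 2, `C#CCN(Cc1ccc2nc(C)nc(O)c2c1)c1ccc(Cl)cc1`, in this assay gives only a limit, > 4000 nM.
Compound 3, `C#CCN(Cc1ccc2nc(C)nc(O)c2c1)c1ccc(C#N)cc1`, in this assay gives only a limit, > 5000 nM.

Compound 2 comes from compound 1 by chloro in place of hydrogen on an aromatic carbon. The step that the two limits leave unreadable from compound 1 to compound 2 cannot be read because the limit of > 6500 nM in this assay, at which 1 of the 3 values shown sits, and the limit of > 4000 nM in this assay, at which 1 of the 3 values shown sits, are both limits of the assay and not numbers. Compound 3 comes from compound 1 by cyano in place of hydrogen on an aromatic carbon; the step that the two limits leave unreadable from compound 1 to compound 3 is likewise unreadable, as is a step that the two limits leave unreadable from compound 2 to compound 3.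

Compound 4, `C#CCN(Cc1ccc2nc(C)nc(O)c2c1)c1ccc(C#N)c(Cl)c1`, is not yet measured and comes from compound 3 by chloro in place of hydrogen on an aromatic carbon. This is the same kind of change as from compound 1 to compound 2, but the place differs: in compound 2 the chloro enters para to a large group, in compound 4 it enters ortho to a cyano group and meta to a large group. The earlier step gives no size to carry over, since all three measured values are limits. For compound 4 the step that the limit leaves unreadable from compound 3 to compound 4 is expected to be small, resting on compound 3 sitting at the limit of > 5000 nM in this assay, at which 1 of the 3 values shown sits. Compound 4 is expected to give 6000 nM in this assay, between 2000 nM and 30000 nM, most likely again reported only as a limit.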

Compound 4, half-maximal inhibitory concentration: 4500 nM
Compound 4: middle estimate off by 1.3-fold (0.12 log units), on the high side; low and high end bracket the measured number.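

In this assay, chloro in place of hydrogen on an aromatic carbon, ortho to a cyano group and meta to a large group, gives an at least 1.1-fold lower number from compound 3 to compound 4 (0.04 log units; that floor lies within the scatter), so this pair shows no change beyond the scatter. The step is known only as a floor because compound 3 sits at a limit of the assay and not at a number: the limit of > 5000 nM in this assay, at which 1 of the 4 values shown sits. The same kind of change from compound 1 to compound 2 cannot be read, nor can the other steps among compound 1, compound 2 and compound 3, so nothing here shows whether the size of the chloro step carries from one core to another, in either direction.

The compounds shown leave open what a step of this kind measures when both ends are numbers. They also leave open how an amine or a carboxylic acid in place of the cyano group, or a longer chain in place of the propargyl chain, would read in this assay.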